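The source may hold more compounds than are shown below. What is called first, only, known or untested is meant among the compounds shown, and "the series" means these compounds.

Of the compounds shown here, two on the shared core have numbers so far. In a functional assay (mast cells) for inhibition, with Rattus norvegicus as the target (a higher number here means that more compound is needed for the effect, a lower number that less compound is needed), compound 1 (`CC1CCC(=NNc2ccccc2)c2ncc(C(=O)O)c(=O)n21`) gives 2200 nM and compound 2 (`CC1CC/C(=N\Nc2ccccc2F)c2ncc(C(=O)O)c(=O)n21`) gives 1200 nM as its half-maximal effective concentration. These two values lie within the usual scatter of each other, so the numbers do not rank the pair and compound 2 simply stands with compound 1 in the same range.

Compound 3 (`COc1ccc(N/N=C2\CCC(C)n3c2ncc(C(=O)O)c3=O)cc1`) is still unmeasured. It carries 4-methoxyphenyl in place of 2-fluorophenyl on an amine nitrogen and keeps the rest of compound 2. Within the data shown here, no pair of measured compounds differs in one place only, so the series offers no direct precedent for this change. Among the measured compounds shown here, the only guide is that compound 2 at 1200 nM sits within the scatter of compound 1 at 2200 nM on the same core. In this assay, from the compounds shown here alone, no step beyond the scatter is expected, and the direction stays open. The estimate amounts to a 1.3-fold higher number from compound 2 to compound 3 (0.10 log units; within the scatter) as the expected step and remains within the scatter. For compound 3 the estimated value is 1500 nM with an expected range from 500 nM to 4500 nM in this read-out.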

Compound 3, half-maximal effective concentration: 128000 nM
Compound 3: the middle estimate sits 85-fold (1.93 log units) below what was measured; measured number above the stated range.
By their numbers in this assay, from the lowest: compounds 2 and 1 (each within the scatter of the next); then compound 3.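

In this assay, the group on the amine nitrogen whose other neighbour is the double-bonded nitrogen proves highly sensitive to change: 4-methoxyphenyl in place of 2-fluorophenyl gives a 110-fold higher number from compound 2 to compound 3 (2.03 log units; beyond the scatter). Among these compounds, this is the first step between compounds that differ in one place, and it shows that this position can move the number well beyond the scatter. It does so although both groups are a six-membered aromatic ring of carbon only, with the entering group differing by its oxygen and its 1 hydrogen-bond acceptor. The data shown offer no measurement that explains the size of this step.

The change alters both the identity of the substituent and its printed ring position, so this single step cannot separate the two. Pairs carrying 2-methoxyphenyl and 4-fluorophenyl on the same amine nitrogen would show whether the large step follows the methoxy group, the position numbered 4, or the two together, while the carboxylic acid and the methyl group of the shared core remain untested by any step here.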